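The source may hold more compounds than are shown below. What is called first, only, known or untested is meant among the compounds shown, and "the series" means these compounds.

Measured so far in a functional assay on CHO cells for positive allosteric modulation of muscarinic acetylcholine receptor M5 (Homo sapiens), read by FLIPR and calcium flux, with a stated time of 1 h; on this read-out higher numbers stand for larger maximal responses and lower numbers for smaller maximal responses:
- compound 1 `O=C1C(=O)N(Cc2ccc(Cl)nc2)c2ccc(OC(F)(F)F)cc21`: 80%
- compound 2 `O=C1C(=O)N(Cc2ccc(-c3ccccc3)nc2)c2ccc(OC(F)(F)F)cc21`: 76%

Compound 2 stands alongside compound 1, the two within the scatter of each other; the step of a number 4 percentage points lower from compound 1 to compound 2 (within the scatter) is the only one in hand. Compound 3 `O=C1C(=O)N(Cc2ccc(-c3ccncc3)nc2)c2ccc(OC(F)(F)F)cc21` is not yet measured. It differs from compound 2 by pyridin-4-yl in place of phenyl on an aromatic carbon. Among the measured compounds shown here, the single measured step, a change at the same aromatic carbon, stayed within the scatter, so no shift beyond the scatter is expected in this assay; the step expected is a number 1 percentage points lower from compound 2 to compound 3 (within the scatter). Compound 3 is estimated at 75%, range 60% to 88%.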

Compound 3, largest response reached (Emax), in percent of the reference or control that the assay uses: 50%
Estimate against measurement, compound 3: 25 percentage points above; the whole stated range lies above it.
By their numbers in this assay, from the lowest: compound 3; then compounds 2 and 1 (each within the scatter of the next).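

In this assay this aromatic carbon proves sensitive to the group it carries: the change reads a number 26 percentage points lower from compound 2 to compound 3 (beyond the scatter) and, against chloro, a number 30 percentage points lower from compound 1 to compound 3 (beyond the scatter). Phenyl and pyridin-4-yl have the same heavy-atom count and differ by one ring nitrogen in place of carbon, so a swap within a single ring at this carbon is enough to lower the maximal response. Nothing available explains this drop.

Going by these compounds, whether the ring nitrogen's location matters stays open, as pyridin-3-yl would test. On these data alone, how an amine such as morpholine would fare at this carbon is also open.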